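The source may hold more compounds than are shown below. What is called first, only, known or untested is meant among the compounds shown, and "the series" means these compounds.

Among the compounds with values here, compound 1 `CC1=NC(c2cn(S(=O)(=O)c3cccs3)c3ccc(C)cc23)CN1` gives 22000 nM in an assay on isolated protein for inhibition of kallikrein-7 (Mus musculus), read by fluorescence, with stated times of 10 min and 30 min (a lower number here means a stronger inhibitor, a higher number a weaker inhibitor), the highest of the two numbers measured so far. Within the data shown here, compound 2 `CC1=NC(c2cn(S(=O)(=O)c3cccc(Cl)c3)c3ccc(C)cc23)CN1` gives 10000 nM in this assay, and the single measured step, a 2.2-fold lower number from compound 1 to compound 2 (0.34 log units; beyond the scatter), replaces the same thiophen-2-yl with a 3-chlorophenyl. Compound 3 `CC1=NC(c2cn(S(=O)(=O)c3ccccc3Cl)c3ccc(C)cc23)CN1` differs from compound 1 by 2-chlorophenyl in place of thiophen-2-yl on a sulfonyl sulfur. Among the measured compounds shown here, a downward step of similar size is expected because a 2.2-fold lower number from compound 1 to compound 2 (0.34 log units; beyond the scatter) was modest, although no measured step covers 2-chlorophenyl as against 3-chlorophenyl. Compound 3 is therefore estimated at 11000 nM in this assay, between 4500 nM and 27000 nM, an expected step of a 2.0-fold lower number from compound 1 to compound 3 (0.30 log units; within the scatter).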

Compound 3, half-maximal inhibitory concentration: 1500 nM
Estimate against measurement, compound 3: 7.3-fold (0.87 log units) above; measured number below the stated range.
By their numbers in this assay, from the lowest: compound 3; then compound 2; then compound 1.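

With 2-chlorophenyl in place of thiophen-2-yl on the sulfonyl sulfur, this assay shows a 15-fold lower number from compound 1 to compound 3 (1.17 log units; beyond the scatter). The two chlorophenyl groups are not interchangeable at this place: 2-chlorophenyl in place of 3-chlorophenyl gives a 6.7-fold lower number from compound 2 to compound 3 (0.82 log units; beyond the scatter), so the position of the chlorine on the phenyl ring matters, and not merely its presence. Nothing available explains this difference. Going by these compounds, whether 2-fluorophenyl, 2-bromophenyl or 2-methoxyphenyl would give a similarly low number remains open, as does the effect of an amine at that ring position.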